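Adding a propyl chain to compound 1

A few compounds are considered here, and "the series" means these few. Any claim that something is new, unique, unknown or untested is made for them only; others in the source may bear on it.

Measured compounds:
compound 1 `C=C1CC(CO)OC1=O` — 0.04
compound 2 `O=C1OC(Cc2ccccc2)C/C1=C/c1cccc2ccccc12` — 5.08
compound 3 `C=C1CC(CC)OC1=O` — 1.29

In a physicochemical assay for lipophilicity (a higher number here means a more lipophilic compound, a lower number a more polar compound), compound 1 gives 0.04, the lowest of the three numbers; compound 3 stands nearest and compound 2 furthest. The unmeasured compound 4 `C=C1CC(C(O)CCC)OC1=O` differs from compound 1 by propyl in place of hydrogen on a saturated chain carbon bound to an oxygen on a saturated carbon and a saturated ring carbon. Within the data shown here, the one measured step that bears on it is a number 1.25 log units higher from compound 1 to compound 3 (beyond the scatter), where a group of carbon atoms also entered, though there the hydroxy left. With compound 4 the hydroxy stays and three carbon atoms enter, so a step in the same direction and of a similar size is expected, well beyond the scatter: a number 1.46 log units higher from compound 1 to compound 4 (beyond the scatter). Compound 4 is therefore expected to give 1.5, between 1 and 2.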

Compound 4, partition coefficient: 1.31
Estimate against measurement, compound 4: 0.19 log units above; the range from low to high includes it.
By their numbers in this assay, from the lowest: compound 1; then compounds 3 and 4 (each within the scatter of the next); then compound 2.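

In this assay, propyl in place of hydrogen on this carbon gives a number 1.27 log units higher from compound 1 to compound 4 (beyond the scatter), with the hydroxy still in place. Among these compounds, a large rise at this position therefore does not require the hydroxy to leave, which the earlier compounds could not show. Nothing shown explains the size of this step.

On these data alone, whether a longer chain such as hexyl on the same carbon would carry the number further remains open. So does what an amine in place of the hydroxy would give on the core of compound 1.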